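The compounds below may be only part of what the source reports. "The series", "measured", "known", "first", "only" and "open" are said of these compounds alone.

Three compounds carrying the shared core of compound 1, `Cc1ccccc1-c1nn(-c2ccc(F)cc2F)cc1CNC1CCN(S(C)(=O)=O)CC1`, have been tested in an ADME assay on Huh-7 cells (Homo sapiens) for cytotoxicity (a lower number here means that less compound is tolerated, a higher number that more compound is tolerated), and every one of them sits at a limit of the assay. In this assay compound 1 gives > 20000 nM, a limit rather than a number. Compound 2, `Cc1ccccc1-c1nn(-c2ccc(F)cc2F)cc1CNCCCN1CCN(C)CC1`, likewise gives only the limit > 20000 nM. Compound 3, `Cc1ccccc1-c1nn(-c2ccc(F)cc2F)cc1CN1CCN(C(C)C)CC1`, also returns the limit > 20000 nM. Among the compounds with values here, the single step between measured neighbours, a step that the two limits leave unreadable from compound 1 to compound 2, cannot be read, since both ends are limits; the one observation that bears on it, (the limit of > 20000 nM in this assay, at which 3 of the 3 values shown sit), says the same of all three values.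

Compound 4, `CCCCCNCc1cn(-c2ccc(F)cc2F)nc1-c1ccccc1C`, has not been measured. Compared with compound 3 it differs as follows: pentylamino in place of 4-isopropylpiperazin-1-yl on a saturated chain carbon bound to an aromatic carbon. Within the data shown here, no measured step speaks to this exchange, so there is no basis for expecting a readable step in this assay in either direction. Compound 4 is therefore expected to land at 20000 nM, within 8000 nM to 60000 nM, most likely reported again only as a limit. The step of a number no higher from compound 3 to compound 4 (the limit leaves the size open) that this estimate implies is expected to be nil.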

Compound 4, half-maximal cytotoxic concentration: 17000 nM
Beside the measured number, compound 4's estimate is 1.2-fold (0.07 log units) above it, within the range that was stated.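

Compound 4 is the first of these compounds to give a number rather than a limit in this assay, where compound 4 gives 17000 nM. The change at this position, pentylamino in place of 4-isopropylpiperazin-1-yl on a saturated chain carbon bound to an aromatic carbon, gives an at least 1.1-fold lower number from compound 3 to compound 4 (0.07 log units; that floor lies within the scatter), and the two related exchanges give an at least 1.1-fold lower number from compound 2 to compound 4 (0.07 log units; that floor lies within the scatter) and an at least 1.1-fold lower number from compound 1 to compound 4 (0.07 log units; that floor lies within the scatter). None of these three steps therefore shows a change beyond the scatter, and the step between compound 1 and compound 2 still cannot be read, since the true size of each remains hidden at the other end: the limit of > 20000 nM in this assay, at which 3 of the 4 values shown sit.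

The compounds shown leave open how large these steps really are. They also leave open whether a shorter chain, a branched chain or a carboxylic acid in place of the pentyl chain would give a readable number.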